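This account rests on a few compounds, and the source may have more. Where it says the series, first, only, none or still open, it means among the compounds named here.

The measured compounds, all tested in a functional assay on CHO.K1 cells for antagonist activity at prostaglandin D2 receptor 2 (Homo sapiens), read by GTPgammaS binding, with a stated time of 1 h; on this read-out higher numbers stand for weaker inhibition and lower numbers for stronger inhibition:

Compound 1, `CNC(=O)c1cccc(S(=O)(=O)c2ccccc2Cc2c3c(n(CC(=O)O)c2C)CCNC3=O)c1`: 240 nM
Compound 2, `COc1ccc(S(=O)(=O)c2ccccc2Cc2c3c(n(CC(=O)O)c2C)CCNC3=O)cc1`: 3.9 nM
Compound 3, `Cc1c(Cc2ccccc2S(=O)(=O)c2ccc(OC(F)(F)F)cc2)c2c(n1CC(=O)O)CCNC2=O`: 6.6 nM

Compound 2 gives the lowest of the three numbers, but its neighbour compound 3 sits close: a 1.7-fold higher number from compound 2 to compound 3 (0.23 log units; within the scatter), so the two cannot be ranked. Compound 1 lies far off, a 62-fold lower number from compound 1 to compound 2 (1.79 log units; beyond the scatter) and a 36-fold lower number from compound 1 to compound 3 (1.56 log units; beyond the scatter).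

Compound 4 is `Cc1c(Cc2ccccc2C(=O)c2ccccc2)c2c(n1CC(=O)O)CCNC2=O`. It differs from compound 2 in one place: benzoyl in place of (4-methoxyphenyl)sulfonyl on an aromatic carbon. For the measured compounds named here, the steps that bear on it are those that swap the aryl group on the sulfonyl sulfur, both large, and the one that exchanges trifluoromethyl for methyl on the aromatic oxygen, which stayed within the scatter. Going by the values given here, none of them alters the sulfonyl group itself, and none removes the substituent on the distal ring altogether, so the move to a bare benzoyl has no direct precedent here. Because compound 2 3.9 nM and compound 3 6.6 nM both sit low while compound 1 240 nM shows how far a change on this ring can reach, a moderate rise is expected in this assay, roughly a 3.8-fold higher number from compound 2 to compound 4 (0.59 log units; beyond the scatter). For compound 4 the expected value is 15 nM, estimated to fall between 3 nM and 80 nM.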

Compound 4, half-maximal inhibitory concentration: 810 nM
Beside the measured number, compound 4's estimate is 54-fold (1.73 log units) below it; measured number above the stated range.
By their numbers in this assay, from the lowest: compounds 2 and 3 (each within the scatter of the next); then compound 1; then compound 4.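

Compounds 1, 2 and 3 all keep the sulfonyl group and vary only the aryl group on its sulfur, so they show nothing about replacing the whole group on this aromatic carbon. Compound 4 does replace it, and the exchange of (4-methoxyphenyl)sulfonyl for benzoyl carries a heavy cost, with a 210-fold higher number from compound 2 to compound 4 (2.32 log units; beyond the scatter) in the inhibition read-out, so a low number in this series is not retained when this benzoyl takes the place of that sulfonyl group. The swap goes from 11 heavy atoms to 8 and from 3 hydrogen-bond acceptors to 1, but no measurement given here accounts for the size of the step.

This single step changes the linking group and removes the methoxy group together, so the compounds shown cannot say how much of the loss belongs to each. As far as these compounds go, a phenylsulfonyl group, or a benzoyl group carrying a methoxy group, would separate the two, and it remains open whether any other link on this carbon, such as a methylene or an ether oxygen, would come closer to compound 2.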